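This account rests on a few compounds, and the source may have more. Where it says the series, first, only, none or still open, it means among the compounds named here.

In a functional assay on RAW264.7 cells (Mus musculus) for inhibition, read by Griess assay, with stated times of 2 h and 24 h (a higher number here means a weaker inhibitor, a lower number a stronger inhibitor), the three measured compounds gave the following:

compound 1 `COc1ccc([C@@H]2C/C(=N\O)c3c(O)cc(OCc4cn(C5CCCC5)nn4)cc3O2)cc1O` — 6880 nM
compound 2 `COc1ccc([C@@H]2CC(=O)c3c(O)cc(OCc4cn(Cc5ccccc5C#N)nn4)cc3O2)cc1O` — 14600 nM
compound 3 `COc1ccc([C@@H]2C/C(=N\O)c3c(O)cc(OCc4cn(Cc5ccccc5F)nn4)cc3O2)cc1O` — 5710 nM

Compound 2 stands with the highest of the three numbers; compound 1 and compound 3 both lie lower, and each of those gaps is beyond the scatter. Compound 4 `COc1ccc([C@@H]2CC(=O)c3c(O)cc(OCc4cn(C5CCC5)nn4)cc3O2)cc1O` differs from compound 2 in one place: cyclobutyl in place of 2-cyanobenzyl on an aromatic nitrogen. Within the data shown here, the only measured step at that aromatic nitrogen is a 1.2-fold lower number from compound 1 to compound 3 (0.08 log units; within the scatter), which swapped a cycloalkyl group for a substituted benzyl group without a change beyond the scatter. Among the measured compounds shown here, no measured step connects compound 2 itself to another compound. On that basis compound 4 is expected to stay close to compound 2, with the step of a 1.3-fold lower number from compound 2 to compound 4 (0.12 log units; within the scatter) not beyond the scatter. The estimate for compound 4 is 11000 nM, with a range of 4500 nM to 27000 nM.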

Compound 4, half-maximal inhibitory concentration: 15300 nM
The estimate for compound 4 lay 1.4-fold (0.14 log units) below the measured number; measured number inside the range.
By their numbers in this assay, from the lowest: compounds 3 and 1 (each within the scatter of the next); then compounds 2 and 4 (each within the scatter of the next).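

In this assay, cyclobutyl in place of 2-cyanobenzyl gave a 1.0-fold higher number from compound 2 to compound 4 (0.02 log units; within the scatter) and so gave compound 2 its first measured neighbour. On this core, the aromatic nitrogen took a group without the six-membered aromatic ring or the nitrile and the number stayed within the scatter, as it had for the cycloalkyl-to-benzyl exchange on the core of compound 1. Nothing available explains this result.

From the compounds shown here alone, whether an amine, a carboxylic acid or a longer alkyl chain on this nitrogen would move the number beyond the scatter remains open.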